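This account rests on a few compounds, and the source may have more. Where it says the series, first, only, none or still open, it means among the compounds named here.

Measured compounds:
Compound 1, `Cc1nnc(CN)n1-c1ccc(Cl)cc1C(O)c1ccccc1`, 4 mg/kg
Compound 2, `Cc1nnc(CN2CCCC2)n1-c1ccc(Cl)cc1C(=O)c1ccccc1`, 2 mg/kg
Compound 3, `Cc1nnc(CN2CCCC2)n1-c1ccc(Cl)cc1C(=O)c1ccccc1Cl`, 4 mg/kg

All three were tested in a functional assay on the whole organism (strain CF-1) for inhibition, with Mus musculus as the target; a lower number here means that less compound is needed, a higher number that more compound is needed for the effect. Compound 3 gives 4 mg/kg, the same at the digits shown as compound 1 and together with it the highest of the three numbers; compound 2 sits lowest, but the distance a 2.0-fold higher number from compound 2 to compound 3 (0.30 log units; within the scatter) is within the scatter, so nothing separates the three with confidence.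

Compound 4, `Cc1nnc(CN2CCCC2)n1-c1ccc(Cl)cc1C(O)c1ccccc1`, has not been measured. It arises from compound 3 by the change (hydroxy(phenyl)methyl in place of (2-chlorophenyl)carbonyl on an aromatic carbon). Going by the values given here, only one measured step touches the same part of the molecule: a 2.0-fold higher number from compound 2 to compound 3 (0.30 log units; within the scatter), which removes only the chloro from this group and stays within the scatter. Among the compounds with values here, no measured pair exchanges the carbonyl for the hydroxymethyl alone, so that part of the change is untested. Compound 1 and compound 2 carry the two groups and differ elsewhere as well, and their values show no gap beyond the scatter. In this assay compound 4 is therefore expected to stay close to compound 3, with a step of a 1.3-fold lower number from compound 3 to compound 4 (0.12 log units; within the scatter), and an estimated value of 3 mg/kg, between 1.5 mg/kg and 7 mg/kg.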

Compound 4, dose for half-maximal effect: 14 mg/kg
Compound 4: middle estimate off by 4.7-fold (0.67 log units), on the low side; measured number outside the range, above it.
By their numbers in this assay, from the lowest: compounds 2, 1 and 3 (each within the scatter of the next); then compound 4.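

Going by these compounds alone, replacing (2-chlorophenyl)carbonyl with hydroxy(phenyl)methyl moves the number beyond the scatter in this assay (a 3.5-fold higher number from compound 3 to compound 4 (0.54 log units; beyond the scatter)), which no earlier step did. The cleanest view of this position comes from benzoyl giving way to hydroxy(phenyl)methyl (a 7.0-fold higher number from compound 2 to compound 4 (0.85 log units; beyond the scatter)): no chloro is involved, so the carbonyl and the hydroxy-bearing carbon are not interchangeable here. The other end of the molecule also counts once hydroxy(phenyl)methyl is in place, as pyrrolidin-1-yl in place of amino on the saturated chain carbon gives a higher number (a 3.5-fold higher number from compound 1 to compound 4 (0.54 log units; beyond the scatter)), although this rests on a single pair.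

Nothing measured here explains why these steps occur. The compounds shown leave open how a methoxy group in place of the hydroxy, or a plain methylene in place of the carbonyl, would behave at this position.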